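Triazolylmethyl esters of a hydroxylated core: varying the aryl group

The source may report more compounds than this note shows. Statements on the series, on what has been measured and on what is new or still open speak of the compounds shown alone.

Compound 1, `C/C(=C\CC/C(C)=C/CC[C@@H]1[C@@]2(C)CCC(=O)C(C)(C)[C@H]2CC[C@@]1(C)O)CC/C=C(\C)C(=O)OCc1cn(-c2cccc(Cl)c2)nn1`, in a functional assay on DU-145 cells (Homo sapiens) for antiproliferative activity, read by MTT assay, with a stated time of 48 h (a higher number here means a weaker inhibitor, a lower number a stronger inhibitor), gives 103000 nM.
Compound 2, `C/C(=C\CC/C(C)=C/CC[C@@H]1[C@@]2(C)CCC(=O)C(C)(C)[C@H]2CC[C@@]1(C)O)CC/C=C(\C)C(=O)OCc1cn(-c2ccc(Cl)cc2)nn1`, reaches only the assay limit > 150000 nM.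
Compound 3, `C/C(=C\CC/C(C)=C/CC[C@@H]1[C@@]2(C)CCC(=O)C(C)(C)[C@H]2CC[C@@]1(C)O)CC/C=C(\C)C(=O)OCc1cn(-c2cccc([N+](=O)[O-])c2)nn1`, likewise shows only the assay limit > 150000 nM.

Among the measured compounds shown here, compound 1 thus holds the only number among the three; the other two sit at the limit (the limit of > 150000 nM in this assay, at which 2 of the 3 values shown sit). The step of an at least 1.4-fold higher number from compound 1 to compound 2 (0.16 log units; that floor lies within the scatter) and the step of an at least 1.4-fold higher number from compound 1 to compound 3 (0.16 log units; that floor lies within the scatter) both run into that limit, each with a floor inside the scatter. Compound 4, `COc1ccccc1-n1cc(COC(=O)/C(C)=C/CC/C(C)=C/CC/C(C)=C/CC[C@@H]2[C@@]3(C)CCC(=O)C(C)(C)[C@H]3CC[C@@]2(C)O)nn1`, brings (2-methoxyphenyl in place of 3-chlorophenyl on an aromatic nitrogen). For the measured compounds named here, no measured step involves a methoxy group. Going by the values given here, the two aryl changes already seen, both ending at the limit, are the only guide. A step of similar size in the same direction, or none beyond the scatter, is expected: a 1.3-fold higher number from compound 1 to compound 4 (0.10 log units; within the scatter). Compound 4 is therefore estimated at 130000 nM, between 60000 nM and 280000 nM.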

Compound 4, half-maximal inhibitory concentration: > 150000 nM
Compound 4 ended at the assay's limit; the forecaster's own chance of this, stated with the estimate: 45%; middle value at least 1.1-fold (0.06 log units) away from the limit.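

The 2-methoxyphenyl group brings a methoxy group and a hydrogen-bond acceptor to this position, yet in this assay compound 4 gives > 150000 nM as a limit and no number. The result is an at least 1.4-fold higher number from compound 1 to compound 4 (0.16 log units; that floor lies within the scatter) and establishes no change beyond the scatter. The steps from compound 2 and from compound 3 to compound 4 cannot be read, and a single limit now holds most of the series: the limit of > 150000 nM in this assay, at which 3 of the 4 values shown sit.

Going by these compounds, whether any aryl group gives a second readable number remains open. An amine or a carboxylic acid on the phenyl ring is untested among the compounds shown.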